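The source may report more compounds than this note shows. Statements on the series, on what has been measured and on what is new or still open speak of the compounds shown alone.

Compound 1 `CCNc1cc(-c2ccc(NC(=O)Nc3c(C)cccc3C)cc2C)ccn1` and compound 2 `CCNc1cc(-c2ccc(NC(=O)Nc3ccccc3Cl)cc2C)ccn1` share a core and differ only at one point: 2-chlorophenyl in place of 2,6-dimethylphenyl on an amide-type nitrogen. In a functional assay on MCF7 cells (Homo sapiens) for cytotoxicity, read by MTT assay, with a stated time of 24 h (on this read-out lower numbers stand for stronger inhibition and higher numbers for weaker inhibition), compound 1 gives 7920 nM, while compound 2 gives 8350 nM, so the change made a 1.1-fold higher number from compound 1 to compound 2 (0.02 log units; within the scatter). Compound 3 `CCNc1cc(-c2ccc(NC(=O)Nc3c(C)cccc3C)cc2OC)ccn1` carries a different core; it differs from compound 1 by methoxy in place of methyl on an aromatic carbon, and in this assay compound 3 gives 9260 nM, which is a 1.2-fold higher number from compound 1 to compound 3 (0.07 log units; within the scatter). Compound 4 `CCNc1cc(-c2ccc(NC(=O)Nc3ccccc3Cl)cc2OC)ccn1` is built on the core of compound 3 and has not yet been measured in this assay. It differs from compound 3 by 2-chlorophenyl in place of 2,6-dimethylphenyl on an amide-type nitrogen, the same change as that from compound 1 to compound 2, at the same place. Because that earlier step was a 1.1-fold higher number from compound 1 to compound 2 (0.02 log units; within the scatter), the expected step here is a 1.1-fold higher number from compound 3 to compound 4 (0.02 log units; within the scatter), resting on one measured pair and on the chance that the core change hardly moved the number. Compound 4 is therefore estimated to give 9800 nM in this assay, with a plausible range from 4900 nM to 19600 nM.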

Compound 4, half-maximal inhibitory concentration: 9940 nM
For compound 4 the middle estimate is 1.0-fold (0.01 log units) below the measured one; the range from low to high includes it.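

Carried from one core to the other in this assay, 2-chlorophenyl in place of 2,6-dimethylphenyl on an amide-type nitrogen gives a 1.1-fold higher number from compound 3 to compound 4 (0.03 log units; within the scatter), which matches the earlier step: the same change on two cores in this assay, a 1.1-fold higher number (0.02 log units; within the scatter) from compound 1 to compound 2 and a 1.1-fold higher number (0.03 log units; within the scatter) from compound 3 to compound 4, 1.0-fold (0.01 log units) apart, within the scatter of two such steps. Methoxy in place of methyl on an aromatic carbon gives a 1.2-fold higher number from compound 2 to compound 4 (0.08 log units; within the scatter), and it matches in the same way: the same change on two cores in this assay, a 1.2-fold higher number (0.07 log units; within the scatter) from compound 1 to compound 3 and a 1.2-fold higher number (0.08 log units; within the scatter) from compound 2 to compound 4, 1.0-fold (0.01 log units) apart, within the scatter of two such steps. Each change therefore reads alike on these two cores, but every step lies within the scatter, so the agreement rests on one pair of small steps per change and does not show that a change with a clear effect would carry over as well.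

The compounds shown leave open whether a carboxylic acid or a longer chain in place of 2-chlorophenyl on the amide-type nitrogen would give a step beyond the scatter. They also leave open whether the two changes would read alike on any core other than these two.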